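A few compounds are considered here, and "the series" means these few. Any claim that something is new, unique, unknown or untested is made for them only; others in the source may bear on it.

Measured so far:
Compound 1 `COc1cccc(/C=C/C[C@H]2C[C@@H]([C@@H](O)c3ccccc3)CO[C@@H]2c2ccccc2)c1`: 9620 nM
Compound 2 `Oc1cccc(/C=C/C[C@H]2C[C@@H]([C@@H](O)c3ccccc3)CO[C@@H]2c2ccccc2)c1`: 12800 nM

For the measured compounds named here, in a functional assay on HL-60 cells (Homo sapiens) for cytotoxicity, read by WST assay, with a stated time of 48 h (on this read-out lower numbers stand for stronger inhibition and higher numbers for weaker inhibition), compound 2 gives 12800 nM, the higher of only two numbers, yet it cannot be told apart from compound 1 at 9620 nM. Compound 3 `Cc1ccc(/C=C/C[C@H]2C[C@@H]([C@@H](O)c3ccccc3)CO[C@@H]2c2ccccc2)cc1C` has 3,4-dimethylphenyl in place of 3-hydroxyphenyl on a double-bonded chain carbon bound to a double-bonded chain carbon. Going by the values given here, one measured step bears on this change: a 1.3-fold higher number from compound 1 to compound 2 (0.12 log units; within the scatter), with hydrogen in place of methyl on an oxygen on an aromatic ring. That step stays within the scatter, so swapping this substituent has so far shown no measurable effect. However, no measured compound lacks that oxygen, so the estimate stays wide. The expected step, a 1.4-fold lower number from compound 2 to compound 3 (0.15 log units; within the scatter), is no larger than the scatter, in either direction. Compound 3 is expected at about 9000 nM, within an estimated range of 4000 nM to 20000 nM.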

Compound 3, half-maximal inhibitory concentration: 9880 nM
Estimate against measurement, compound 3: 1.1-fold (0.04 log units) below, within the range that was stated.
By their numbers in this assay, from the lowest: compounds 1, 3 and 2 (each within the scatter of the next).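

In this assay, putting 3,4-dimethylphenyl in place of 3-hydroxyphenyl gives a 1.3-fold lower number from compound 2 to compound 3 (0.11 log units; within the scatter) and putting it in place of 3-methoxyphenyl gives a 1.0-fold higher number from compound 1 to compound 3 (0.01 log units; within the scatter) on the same double-bonded chain carbon. Both members of the earlier pair carried an oxygen on the ring, whereas compound 3 has a ring of carbon only with no hydrogen-bond donor or acceptor, and its number still cannot be told apart from theirs. No measurement offered here explains this flat result.

As far as these compounds go, all three rings at this place are uncharged, so it remains open how a ring carrying an amine or a carboxylic acid would read. From the compounds shown here alone, it also remains open whether a longer chain at this place would move the number beyond the scatter.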